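Swapping a Pyrazole Amide for a Thiophene Sulfonamide

The source may hold more compounds than are shown below. What is called first, only, known or untested is meant among the compounds shown, and "the series" means these compounds.

Measured compounds:
Compound 1, `CCN1CCN(c2cccc3c2CN([C@H](CCCNC(=O)c2c(C)n[nH]c2C)c2ccc(OC)c(OC)c2)C3=O)CC1`: 130 nM
Compound 2, `COc1ccc([C@@H](CCCN(C)S(=O)(=O)c2cccs2)N2Cc3c(cccc3N3CCN(C)CC3)C2=O)cc1OC`: 340 nM

Both compounds were tested in a functional assay on RMS13 cells for antagonist activity at Urotensin-2 receptor (Homo sapiens), read by FLIPR and calcium flux, with a stated time of 1 h; on this read-out higher numbers stand for weaker inhibition and lower numbers for stronger inhibition. Compound 1 gives the lower of the two numbers, 130 nM, while compound 2 gives 340 nM, a gap that lies beyond the usual scatter of this assay. Compound 2 differs from compound 1 in more than one place, so its value alone does not tell which change matters.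

Compound 3, `CCN1CCN(c2cccc3c2CN([C@H](CCCN(C)S(=O)(=O)c2cccs2)c2ccc(OC)c(OC)c2)C3=O)CC1`, has not been measured. It keeps the core of compound 1 and changes only the side chain: methyl((thiophen-2-yl)sulfonyl)amino in place of ((3,5-dimethyl-1H-pyrazol-4-yl)carbonyl)amino on a saturated chain carbon, four bonds along the chain from an amide-type nitrogen in a ring and an aromatic carbon. This brings in the same chain ending that compound 2 carries, while the rest of compound 1 stays untouched.

Among the compounds with values here, no single-change step is available to set the size of this move. Since compound 2, which shares this chain ending, gives 340 nM, a modest loss against compound 1 is expected, though one that may fall within the scatter; the step from compound 1 to compound 3 is estimated at a 1.8-fold higher number from compound 1 to compound 3 (0.27 log units; within the scatter). Compound 3 is therefore expected to give about 240 nM, within a range of 90 nM to 650 nM.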

Compound 3, half-maximal inhibitory concentration: 88 nM
The estimate for compound 3 lay 2.7-fold (0.44 log units) above the measured number; measured number outside the range, below it.
By their numbers in this assay, from the lowest: compounds 3 and 1 (each within the scatter of the next); then compound 2.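

In this assay, methyl((thiophen-2-yl)sulfonyl)amino in place of ((3,5-dimethyl-1H-pyrazol-4-yl)carbonyl)amino gives a 1.5-fold lower number from compound 1 to compound 3 (0.17 log units; within the scatter), so at this place on the chain the assay does not tell the two groups apart, even though the entering group has no hydrogen-bond donors and the leaving group has some. The comparison with compound 2 shows a separate effect: methyl in place of hydrogen on a saturated chain carbon bound to an amine nitrogen in a ring gives a 3.9-fold lower number from compound 2 to compound 3 (0.59 log units; beyond the scatter), and this small addition, not the side-chain swap, is the step that lies beyond the scatter. Nothing measured here explains either step.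

The compounds shown leave open whether a longer chain, such as propyl, would extend the step seen at the ring amine, and whether that step would hold with the ((3,5-dimethyl-1H-pyrazol-4-yl)carbonyl)amino group in place. They also leave open whether a phenyl ring could stand in for the thiophene, and what role the methyl on the sulfonamide nitrogen plays.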